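Swapping Chloro for Fluoro on a Second Core

The compounds below may be only part of what the source reports. "The series", "measured", "known", "first", "only" and "open" are said of these compounds alone.

Two cores carry the same pendant ring. Compound 1 `Cc1cc(C)c2c(O)cc(-c3cccc(F)c3)nc2n1` and compound 2 `Cc1cc(C)c2c(O)cc(-c3cccc(Cl)c3)nc2n1` share one core; in a functional assay on NCI-H460 cells (Homo sapiens) for antiproliferative activity (on this read-out higher numbers stand for weaker inhibition of growth and lower numbers for stronger inhibition of growth), compound 1 gives 53.7 nM and compound 2 gives 224 nM. Between them stands a single change, (fluoro in place of chloro on an aromatic carbon), with the step of a 4.2-fold lower number from compound 2 to compound 1 (0.62 log units; beyond the scatter). Compound 3 `Cc1cnc2[nH]c(-c3cccc(Cl)c3)cc(=O)c2c1` has a different core; the difference between the two cores is not broken down here. In this assay compound 3 gives 50.1 nM, close to compound 1 and well apart from compound 2. Compound 4 `Cc1cnc2[nH]c(-c3cccc(F)c3)cc(=O)c2c1` repeats the same change on the core of compound 3: fluoro in place of chloro on an aromatic carbon. Going by the values given here, compound 4 is expected to show a 2.5-fold lower number from compound 3 to compound 4 (0.40 log units; beyond the scatter), a somewhat smaller step than the earlier one, because the only precedent is a 4.2-fold lower number from compound 2 to compound 1 (0.62 log units; beyond the scatter) on another core. Compound 4 is estimated at 20 nM, between 7 nM and 60 nM.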

Compound 4, concentration for 50% growth inhibition: 38.9 nM
The estimate for compound 4 lay 1.9-fold (0.29 log units) below the measured number; measured number inside the range.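

On the core of compound 3, putting fluoro in place of chloro gives, in this assay, a 1.3-fold lower number from compound 3 to compound 4 (0.11 log units; within the scatter), so here the swap makes no clear difference. The size of the step therefore did not carry over from one core to the other: the same change on two cores in this assay, a 4.2-fold lower number (0.62 log units; beyond the scatter) from compound 2 to compound 1 and a 1.3-fold lower number (0.11 log units; within the scatter) from compound 3 to compound 4, 3.2-fold (0.51 log units) apart, beyond the scatter of two such steps. This shows that a step seen on one core is an uncertain guide to the same change on another, but two pairs cannot explain the mismatch or predict how a further core would behave.

As far as these compounds go, it remains open how other groups at this place on the pendant ring, such as an amine or a methoxy, would fare on either core. The compounds shown also leave open which part of the difference between the two cores matters.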